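This account rests on a few compounds, and the source may have more. Where it says the series, first, only, none or still open, it means among the compounds named here.

Of the compounds shown here, three built on one shared core have been measured in a functional assay on ACHN cells (Homo sapiens) for antiproliferative activity, read by XTT assay; a higher number here means a weaker inhibitor, a lower number a stronger inhibitor. Compound 1 `CC(C)COc1cccc2occ(Cc3coc4ccccc4c3=O)c(=O)c12` gives 1460 nM. Compound 2 `COc1ccc2c(=O)c(Cc3coc4cccc(OCC5CCCCC5)c4c3=O)coc2c1` gives 1350 nM, and compound 3 `O=c1c(Cc2coc3cccc(OCC4CCCCC4)c3c2=O)coc2cc(O)ccc12` gives 2100 nM. Compound 1 sits within the usual scatter of both companions, so the three cannot be told apart on these numbers.

Compound 4 `O=c1c(Cc2coc3cccc(O)c3c2=O)coc2ccccc12` has not yet been measured. It differs from compound 1 in one place: hydrogen in place of isobutyl on an oxygen on an aromatic ring, that is, isobutoxy becomes hydroxy. Within the data shown here, the only measured step that resembles this is the loss of a methyl from an aromatic oxygen: a 1.6-fold higher number from compound 2 to compound 3 (0.19 log units; within the scatter). That change stays inside the scatter, and it removes a smaller group than the isobutyl lost here, so it is weak evidence. Among the measured compounds shown here, no other pair of measured compounds speaks to this change.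

On that basis no step beyond the scatter is expected from compound 1 to compound 4, giving a 1.2-fold higher number from compound 1 to compound 4 (0.07 log units; within the scatter) in this assay. Compound 4 is therefore estimated at 1700 nM, with a range from 700 nM to 4000 nM.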

Compound 4, half-maximal inhibitory concentration: 740 nM
Compound 4: the middle estimate sits 2.3-fold (0.36 log units) above what was measured, and the stated range covers the measured number.
By their numbers in this assay, from the lowest: compounds 4, 2, 1 and 3 (each within the scatter of the next, the first and the last beyond it).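

In this assay, replacing the isobutyl on the aromatic oxygen with hydrogen gives a 2.0-fold lower number from compound 1 to compound 4 (0.30 log units; within the scatter) and stays within the scatter. Until now, this place had carried only oxygen-linked carbon groups, the isobutoxy of compound 1 and the cyclohexylmethoxy of compound 2 and compound 3, so none of them showed how the shared core behaves with a plain hydroxy here. Compound 4 shows that the isobutyl is not needed for a number of this order in this cell assay, although nothing available here offers an explanation for the result.

The compounds shown leave open how a methyl, a longer chain, an amine or a carboxylic acid would read at this place. They also leave open whether a hydroxy here would give a similar reading alongside the methoxy of compound 2.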